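The source may hold more compounds than are shown below. What is called first, only, known or untested is meant among the compounds shown, and "the series" means these compounds.

Working notes on the series. In an assay on cells for binding affinity to 5-hydroxytryptamine receptor 1B (Homo sapiens), read by radioligand binding (on this read-out lower numbers stand for stronger inhibition and higher numbers for weaker inhibition), compound 1 `NC(=O)c1ccc2c(c1)CCOC2CCN1CC=C(c2csc3cc(F)ccc23)CC1` gives 186 nM. Compound 2 `NC(=O)c1ccc2c(c1)CCOC2CCN1CC=C(c2cccc3ccccc23)CC1` gives 153 nM in this assay. The one measured step, a 1.2-fold lower number from compound 1 to compound 2 (0.08 log units; within the scatter), is within the scatter; compound 2 thus carries the smaller of the two numbers shown, but the gap to compound 1 says nothing beyond noise.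

Compound 3 `NC(=O)c1ccc2c(c1)CCOC2CCN1CC=C(c2[nH]nc3cc(F)ccc23)CC1` is not yet measured. It differs from compound 2 by 6-fluoro-2H-indazol-3-yl in place of naphthalen-1-yl on a double-bonded ring carbon. Within the data shown here, the only step at this position, a 1.2-fold lower number from compound 1 to compound 2 (0.08 log units; within the scatter), swapped one fused bicyclic group for another without a hydrogen-bond donor and moved the number within the scatter. Among the measured compounds shown here, no measured step covers a group with a donor and an acceptor here, so direction is open. Compound 3 is expected in this assay near compound 2, at 170 nM with a range of 45 nM to 650 nM. This estimate means an expected step of a 1.1-fold higher number from compound 2 to compound 3 (0.05 log units; within the scatter).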

Compound 3, inhibition constant: 210 nM
Beside the measured number, compound 3's estimate is 1.2-fold (0.09 log units) below it; measured number inside the range.
By their numbers in this assay, from the lowest: compounds 2, 1 and 3 (each within the scatter of the next).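

In this assay, the change to 6-fluoro-2H-indazol-3-yl, the only group shown here with a hydrogen-bond donor and a hydrogen-bond acceptor at this position, stays within the scatter against naphthalen-1-yl (a 1.4-fold higher number from compound 2 to compound 3 (0.14 log units; within the scatter)) and against 6-fluoro-1-benzothiophen-3-yl (a 1.1-fold higher number from compound 1 to compound 3 (0.05 log units; within the scatter)). Among these three fused bicyclic groups, therefore, adding the donor and acceptor does not separate compound 3 from compound 1 or compound 2, and none of the three can be ranked. No supporting evidence bears on this result.

The compounds shown leave open whether a group outside this fused bicyclic type, such as a single phenyl ring or a piperidine, would move the number beyond the scatter. They also leave open how the indazole itself responds to a carboxylic acid or an amine in place of its fluorine.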